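Trifluoromethylphenyl to Fluorophenyl on the Acyl Urea Fragment

The source may hold more compounds than are shown below. What is called first, only, known or untested is meant among the compounds shown, and "the series" means these compounds.

Of the compounds shown here, two have been measured in a functional assay on HeLa cells (Homo sapiens) for inhibition, read by MTT assay, with a stated time of 72 h; a higher number here means a weaker inhibitor, a lower number a stronger inhibitor. Compound 1 `CN(C(=O)NC(=O)c1cccc(C(F)(F)F)c1)c1nc(C(F)(F)F)c(C(=O)N/N=C/c2ccc(C(F)(F)F)cc2)s1` gives 7.35 ug/mL. Compound 2 `CN(C(=O)NC(=O)c1cccc(C(F)(F)F)c1)c1nc(C(F)(F)F)c(C(=O)N/N=C/c2ccccc2C(F)(F)F)s1` gives 7.37 ug/mL. For the measured compounds named here, compound 2 thus carries the highest of the two numbers, and its nearest neighbour is compound 1, at a distance well within the scatter; the only measured step, a 1.0-fold higher number from compound 1 to compound 2 (0.00 log units; within the scatter), shows that swapping the substitution pattern of the aryl group on the carbon with a double bond to nitrogen left the read-out essentially unchanged.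

Compound 3 `CN(C(=O)NC(=O)c1ccccc1F)c1nc(C(F)(F)F)c(C(=O)N/N=C/c2ccccc2C(F)(F)F)s1` is not yet measured. It differs from compound 2 in the acyl urea fragment: 2-fluorophenyl in place of 3-(trifluoromethyl)phenyl on a carbonyl carbon. Going by the values given here, no measured step touches this position, so the step from compound 1 to compound 2, which concerns a different part of the molecule, gives only indirect guidance that small aryl changes have not moved the number. With nothing else to draw on, the expected step is a 1.0-fold higher number from compound 2 to compound 3 (0.00 log units; within the scatter), that is, no change beyond the scatter. Compound 3 is therefore estimated at 7.4 ug/mL, with a range from 3 ug/mL to 18 ug/mL.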

Compound 3, half-maximal inhibitory concentration: 10.1 ug/mL
Beside the measured number, compound 3's estimate is 1.4-fold (0.14 log units) below it, within the range that was stated.
By their numbers in this assay, from the lowest: compounds 1, 2 and 3 (each within the scatter of the next).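

In this assay, the acyl urea fragment now has a measured step of its own: 2-fluorophenyl in place of 3-(trifluoromethyl)phenyl on a carbonyl carbon gives a 1.4-fold higher number from compound 2 to compound 3 (0.14 log units; within the scatter). This exchange goes from a group of 10 heavy atoms to one of 7 and from three fluorines to one, yet the read-out stays within the usual scatter, something the earlier step, confined to the aryl group on the carbon with a double bond to nitrogen, could not show for this position. Nothing at hand offers an explanation for this result.

The group and its place on the ring change together in this single step, and the data cannot separate the two, for instance by showing how 3-fluorophenyl or 2-(trifluoromethyl)phenyl would read on the same carbonyl carbon. On these data alone, both groups compared here are fluorine-bearing phenyl rings, and it remains open whether a phenyl ring carrying an amine or a carboxylic acid, or a longer alkyl chain in place of the ring, would also leave the number within the scatter.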